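Halogen changes on the pendant aryl ring: working notes

A few compounds are considered here, and "the series" means these few. Any claim that something is new, unique, unknown or untested is made for them only; others in the source may bear on it.

Measured in a functional assay on HCT-116 cells (Homo sapiens) for inhibition, read by MTT assay, with a stated time of 48 h, tested at 1 mg/mL; on this read-out lower numbers stand for less inhibition and higher numbers for more inhibition at the one concentration tested (going by the name of the read-out):
- compound 1 `N#CC1=C(N)N2C(=O)CSC2=C(C#N)C1c1ccc(F)cc1` gives 47.8%
- compound 2 `N#CC1=C(N)N2C(=O)CSC2=C(C#N)C1c1ccc(Br)cc1` gives 43.6%
- compound 3 `N#CC1=C(N)N2C(=O)CSC2=C(C#N)C1c1ccccc1Cl` gives 54.1%

Compound 3 has the highest of the three numbers in this assay; the nearest is compound 1, a gap within the scatter, and the furthest is compound 2, a gap beyond it. The measured steps are a number 4.2 percentage points lower from compound 1 to compound 2 (within the scatter), a number 6.3 percentage points higher from compound 1 to compound 3 (within the scatter) and a number 10.5 percentage points higher from compound 2 to compound 3 (beyond the scatter).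

Compound 4 `N#CC1=C(N)N2C(=O)CSC2=C(C#N)C1c1ccccc1` differs from compound 3 by hydrogen in place of chloro on an aromatic carbon. Among the compounds with values here, no measured step removes a halogen outright; the closest comparisons are the swaps of one halogenated aryl ring for another, of which only a number 10.5 percentage points higher from compound 2 to compound 3 (beyond the scatter) exceeds the scatter, and only modestly. A step in this assay of no more than the scatter is therefore expected for compound 4, if anything slightly downward, as a number 6.1 percentage points lower from compound 3 to compound 4 (within the scatter). The estimate for compound 4 is 48%, with a range from 35% to 60%.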

Compound 4, a percentage reported as inhibition, at one concentration (the size of the read-out at that concentration, not a potency): 50.8%
Compound 4: the middle estimate sits 2.8 percentage points below what was measured; low and high end bracket the measured number.
By their numbers in this assay, from the lowest: compounds 2, 1, 4 and 3 (each within the scatter of the next, the first and the last beyond it).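

In this assay taking the halogen off the aryl ring altogether stays within the scatter, with the steps reading a number 3.3 percentage points lower from compound 3 to compound 4 (within the scatter) and a number 7.2 percentage points higher from compound 2 to compound 4 (within the scatter) and a number 3 percentage points higher from compound 1 to compound 4 (within the scatter) in turn. A halogen at this position is therefore not required for the level of inhibition seen with chloro, bromo or fluoro. Nothing at hand explains this result.

As far as these compounds go, whether a non-halogen group on this ring, such as an amine or a carboxylic acid, moves the number beyond the scatter stays open. The single tested concentration also leaves potency open.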